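The compounds below may be only part of what the source reports. "The series", "measured", "known", "first", "only" and "open" are said of these compounds alone.

Three compounds share a core in which a phenylethynyl-bearing bicyclic amine is acylated; they differ only in the group on the carbonyl carbon. Compound 1 `CC1CC(C(=O)N2CCc3nc(C#Cc4ccccc4)sc3C2)C1` gives 81 nM in an assay on HEK293 cells for positive allosteric modulation of metabotropic glutamate receptor 5 (Homo sapiens), read by FLIPR, with a stated time of 1 h; a higher number here means that more compound is needed for the effect, a lower number that less compound is needed. Compound 2 `O=C(C1CCCC1)N1CCc2nc(C#Cc3ccccc3)sc2C1` gives 19 nM in this assay, and compound 3 `O=C(C1CCCO1)N1CCc2nc(C#Cc3ccccc3)sc2C1` gives 790 nM. Compound 3 therefore stands highest of the three numbers: the step of a 9.8-fold higher number from compound 1 to compound 3 (0.99 log units; beyond the scatter) and the step of a 42-fold higher number from compound 2 to compound 3 (1.62 log units; beyond the scatter) are both beyond the scatter, while a 4.3-fold lower number from compound 1 to compound 2 (0.63 log units; beyond the scatter) runs the other way.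

Compound 4 `O=C(C1CCOCC1)N1CCc2nc(C#Cc3ccccc3)sc2C1` changes compound 3 by oxan-4-yl in place of oxolan-2-yl on a carbonyl carbon. Among the compounds with values here, no measured step covers exactly this change. The nearest comparison is a 42-fold higher number from compound 2 to compound 3 (1.62 log units; beyond the scatter), where a ring carbon gave way to a ring oxygen and the number rose greatly; compound 4 keeps one hetero atom in the ring but enlarges the ring to six members and shifts the attachment, so part of that rise might be undone, though how much cannot be read from the three values. The step of a 3.2-fold lower number from compound 3 to compound 4 (0.50 log units; beyond the scatter) is therefore expected to be a modest fall in this assay. For compound 4 the estimated value is 250 nM, with a range from 60 nM to 1500 nM.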

Compound 4, half-maximal effective concentration: 290 nM
Compound 4: the middle estimate sits 1.2-fold (0.06 log units) below what was measured; the measured number falls inside the stated range.
By their numbers in this assay, from the lowest: compound 2; then compound 1; then compound 4; then compound 3.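

In this assay, oxan-4-yl in place of oxolan-2-yl on the carbonyl carbon gives a 2.7-fold lower number from compound 3 to compound 4 (0.44 log units; beyond the scatter) in a change where ring size and point of attachment shift together, so a ring with one oxygen at this position is not tied to a single level. The six-membered ring still does not reach the level of the all-carbon groups: the record shows a 15-fold higher number from compound 2 to compound 4 (1.18 log units; beyond the scatter) and a 3.6-fold higher number from compound 1 to compound 4 (0.55 log units; beyond the scatter) for the same replacement of those groups. Among the four compounds shown, both oxygen-bearing rings therefore give higher numbers than both all-carbon rings, and no compound goes against this order. Nothing available here bears on why these numbers differ.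

The compounds shown leave open how much of the fall from compound 3 to compound 4 belongs to the larger ring and how much to the shifted attachment, a question that oxan-2-yl or oxolan-3-yl on the same carbonyl carbon would help to separate. Also open, on these data alone, is where cyclohexyl, the all-carbon counterpart of oxan-4-yl, would stand in this order.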